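A change on the carbonyl carbon of compound 2

The source may report more compounds than this note shows. Statements on the series, on what has been measured and on what is new or still open speak of the compounds shown alone.

Measured in a functional assay on PC-3 cells (Homo sapiens), read by MTT assay, with a stated time of 48 h; on this read-out lower numbers stand for stronger inhibition and higher numbers for weaker inhibition:
Compound 1 `CCN(CC)CCNC(=O)c1ccc(C(CC)(CC)c2ccc(OCC(=O)C(C)(C)C)c(C)c2)n1CC`: 30 nM
Compound 2 `CCN(CC)CCCNC(=O)c1ccc(C(CC)(CC)c2ccc(OCC(O)C(C)(C)C)c(C)c2)n1CC`: 2500 nM

Of these two compounds, compound 2 holds the higher number at 2500 nM, while compound 1 gives 30 nM, a gap beyond the usual scatter. Within the data shown here, no measured pair here differs in only one place, so the data contain no single-change step to draw on.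

Compound 3 `C#CC(C)OC(=O)c1ccc(C(CC)(CC)c2ccc(OCC(O)C(C)(C)C)c(C)c2)n1CC` differs from compound 2 in one place: (1-methylprop-2-yn-1-yl)oxy in place of (3-(diethylamino)propyl)amino on a carbonyl carbon. Here (1-methylprop-2-yn-1-yl)oxy stands in place of (3-(diethylamino)propyl)amino on a carbonyl carbon. The effect of this replacement has not been measured. The expectation therefore rests on compound 2 at 2500 nM, the closest measured structure, and it remains uncertain. In this assay, no step beyond the scatter is expected in either direction. The estimate corresponds to an expected 1.2-fold higher number from compound 2 to compound 3 (0.08 log units; within the scatter). The expected value for compound 3 is 3000 nM, with an estimated range from 600 nM to 15000 nM.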

Compound 3, half-maximal inhibitory concentration: 38200 nM
Compound 3: middle estimate off by 13-fold (1.10 log units), on the low side, and the stated range ends below it.
By their numbers in this assay, from the lowest: compound 1; then compound 2; then compound 3.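

In this assay, among these compounds, the carbonyl carbon of compound 2 proves sensitive to what it carries: (1-methylprop-2-yn-1-yl)oxy in place of (3-(diethylamino)propyl)amino gives a 15-fold higher number from compound 2 to compound 3 (1.18 log units; beyond the scatter), the first step here that can be read for a single change, since compound 1 and compound 2 differ in more than one place. The change is not a simple one, as a group of 9 heavy atoms with 2 nitrogens and 1 hydrogen-bond donor gives way to one of 5 heavy atoms with 1 oxygen, a triple bond and no hydrogen-bond donor, so the step belongs to the exchange as a whole and not to any one of these features. Nothing available bears on why the number rises at this position.

The compounds shown leave open whether the step follows the loss of the diethylamino end, the shorter group or the oxygen in place of the nitrogen on the carbonyl carbon. From the compounds shown here alone, a (3-(diethylamino)propyl)oxy group or a (1-methylprop-2-yn-1-yl)amino group on the same carbon would pull these apart, and a carboxylic acid there is equally open.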